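This account rests on a few compounds, and the source may have more. Where it says the series, first, only, none or still open, it means among the compounds named here.

Measured compounds:

Compound 1, `O=C(/C=C/c1ccc(F)cc1)NS(=O)(=O)c1ccc(Cl)cc1`, gives 2.6 ug/mL in a functional assay on B16-F10 cells (Mus musculus) for antiproliferative activity, read by ELISA and MTT assay, with a stated time of 48 h; on this read-out lower numbers stand for stronger inhibition and higher numbers for weaker inhibition.
Compound 2, `O=C(/C=C/c1ccc(F)cc1)NS(=O)(=O)c1ccc(Br)cc1`, gives 2.8 ug/mL in this assay.
Compound 3, `O=C(/C=C/c1ccc(Cl)cc1)NS(=O)(=O)c1ccccc1`, gives 2.2 ug/mL in this assay.

The three compounds share a cinnamoyl sulfonamide framework in which two aromatic rings flank the central chain. In compound 1 and compound 2 one ring carries a fluoro group, and the other ring carries a halogen that is the point of difference between them. The change from compound 1 to compound 2 is bromo in place of chloro on an aromatic carbon, and it gives a 1.1-fold higher number from compound 1 to compound 2 (0.03 log units; within the scatter). Compound 3 has the core of compound 1 altered in more than one place; the difference between the two cores is not broken down here, and the two values are close to each other.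

Compound 4, `O=C(/C=C/c1ccc(Br)cc1)NS(=O)(=O)c1ccccc1`, has not been measured yet. It differs from compound 3 by bromo in place of chloro on an aromatic carbon. This is the same change as that from compound 1 to compound 2, made at the same kind of place on the ring, and the earlier step was small. The expectation rests on that step: compound 4 is expected to move by a 1.1-fold higher number from compound 3 to compound 4 (0.04 log units; within the scatter) relative to compound 3, a step that stays within the usual scatter. Compound 4 is therefore estimated at 2.4 ug/mL in this assay, with a likely range from 1.5 ug/mL to 4 ug/mL.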

Compound 4, half-maximal inhibitory concentration: 3.9 ug/mL
Estimate against measurement, compound 4: 1.6-fold (0.21 log units) below; the range from low to high includes it.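

In this assay, putting bromo in place of chloro on the 4-chlorophenyl group gives a 1.8-fold higher number from compound 3 to compound 4 (0.25 log units; within the scatter), so compound 4 cannot be told apart from compound 3 in this test. Set beside the earlier case of the same swap, the new step does not differ from it by more than repeated measurements would: the same change on two cores in this assay, a 1.1-fold higher number (0.03 log units; within the scatter) from compound 1 to compound 2 and a 1.8-fold higher number (0.25 log units; within the scatter) from compound 3 to compound 4, 1.6-fold (0.22 log units) apart, within the scatter of two such steps. This shows that, on these two cores, the swap from chloro to bromo produced no change that stands clear of the scatter, but it does not show that the two steps are truly equal in size, and two pairs of compounds cannot establish a rule for other cores in the series.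

The rings in the compounds shown carry only fluoro, chloro, bromo or hydrogen, which leaves open how the read-out would respond to a different kind of group there, such as an amine, a methoxy group or a carboxylic acid. Also open, as far as these compounds go, are the effect of a longer chain joining the two aromatic rings and whether the swap from chloro to bromo would stay within the scatter on a third core.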